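The source may report more compounds than this note shows. Statements on the series, on what has been measured and on what is new or still open speak of the compounds shown alone.

Measured so far in an assay for activation of Adrenergic receptor alpha-1 (Rattus norvegicus); on this read-out higher numbers stand for an effect only at larger amounts of compound and lower numbers for an effect already at smaller amounts:
compound 1 `c1ccc2c(c1)CC2CCCN1CCN(c2cccc3c2OCCO3)CC1` — 0.45 mg/kg
compound 2 `C1=C(CCN2CCN(c3cccc4c3OCCO4)CC2)c2ccccc2C1` — 0.3 mg/kg
compound 3 `C1=C(CCN2CCN(c3cccc4c3OCCO4)CC2)Cc2ccccc21` — 0.17 mg/kg

Compound 3 gives the lowest number of the three. Against compound 2 the gap is within the scatter, so no order between them can be read; against compound 1 it is beyond the scatter, as seen in a 2.6-fold lower number from compound 1 to compound 3 (0.42 log units; beyond the scatter). The step of a 1.5-fold lower number from compound 1 to compound 2 (0.18 log units; within the scatter) stays within the scatter, and so does a 1.8-fold lower number from compound 2 to compound 3 (0.25 log units; within the scatter).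

Compound 4 `Clc1cccc2c1CC2CCN1CCN(c2cccc3c2OCCO3)CC1` has not yet been measured. Its change from compound 3: a group of 9 heavy atoms (8 carbon, 1 chlorine; one four-membered non-aromatic ring of carbon only, one six-membered aromatic ring of carbon only) in place of a group of 9 heavy atoms (9 carbon; one five-membered non-aromatic ring of carbon only, one six-membered aromatic ring of carbon only), on a saturated chain carbon, two bonds along the chain from an amine nitrogen in a ring. The measured step that bears on it is a 2.6-fold lower number from compound 1 to compound 3 (0.42 log units; beyond the scatter), which runs in the opposite direction, a five-membered ring entering for a four-membered one. Here the four-membered ring returns, now carrying chlorine, for which no measured step exists. A modest rise in the number is therefore expected for compound 4, on the order of a 2.1-fold higher number from compound 3 to compound 4 (0.31 log units; beyond the scatter). The estimate for compound 4 in this assay is 0.35 mg/kg, with a range from 0.15 mg/kg to 0.85 mg/kg.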

Compound 4, dose for half-maximal effect: 20 mg/kg
For compound 4 the middle estimate is 57-fold (1.76 log units) below the measured one, and the stated range ends below it.
By their numbers in this assay, from the lowest: compounds 3, 2 and 1 (each within the scatter of the next, the first and the last beyond it); then compound 4.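

Earlier changes at this position, on a saturated chain carbon, two bonds along the chain from an amine nitrogen in a ring, moved the number in this assay only within or just beyond the scatter, whereas the group carrying chlorine brings a much larger shift: a 120-fold higher number from compound 3 to compound 4 (2.07 log units; beyond the scatter) and also a 67-fold higher number from compound 2 to compound 4 (1.82 log units; beyond the scatter). The four-membered ring is present on both sides of a 44-fold higher number from compound 1 to compound 4 (1.65 log units; beyond the scatter) and that step is still large, so ring size alone does not set the high number of compound 4. Nothing measured here gives a reason for this rise.

The compounds shown hold no pair that differs by the chlorine alone, so its share of the rise stays unresolved. From the compounds shown here alone, how a fluorine or a methoxy group in the place of the chlorine would read in this assay also stays open.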